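Sulfonamide Variation at a Sulfonyl Sulfur in Rat Trachea

The source may hold more compounds than are shown below. What is called first, only, known or untested is meant among the compounds shown, and "the series" means these compounds.

Measured so far in a functional assay on the whole organism (trachea) with Rattus norvegicus as the target; on this read-out higher numbers stand for larger maximal responses and lower numbers for smaller maximal responses:
Compound 1 `CC1(C)C=C(n2ccccc2=O)c2cc(S(=O)(=O)Nc3ccccc3)ccc2O1` gives 7.85%; 88% (2 entries).
Compound 2 `CC1(C)C=C(n2ccccc2=O)c2cc(S(=O)(=O)Nc3ccc(C#N)cc3)ccc2O1` gives 90.8%.
Compound 3 `CC1(C)C=C(n2ccccc2=O)c2cc(S(=O)(=O)N3CCOCC3)ccc2O1` gives 85.1%.

Compound 3 holds the lower of the two single numbers, and its nearest neighbour is compound 2; the step of a number 5.7 percentage points lower from compound 2 to compound 3 (within the scatter) lies within the usual scatter of repeated measurements. Compound 1 stands apart, since its two entries disagree widely the several entries of compound 1 in this assay, 7.85%; 88% (2 entries) and yield no single number to compare.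

Compound 4 `CN(c1ccccc1)S(=O)(=O)c1ccc2c(c1)C(n1ccccc1=O)=CC(C)(C)O2` differs from compound 3 in one place: methyl(phenyl)amino in place of morpholin-4-yl on a sulfonyl sulfur. For the measured compounds named here, the only measured step at this sulfonyl sulfur, a number 5.7 percentage points lower from compound 2 to compound 3 (within the scatter), exchanged (4-cyanophenyl)amino for morpholin-4-yl and moved the maximal response by less than the scatter. Putting methyl(phenyl)amino in that place is expected to leave the maximal response similarly unchanged. Compound 4 is therefore expected to give 85%, with a range from 55% to 98%. The expected step of a number 0.1 percentage points lower from compound 3 to compound 4 (within the scatter) thus stays within the scatter, with the wider lower bound reflecting the spread seen in compound 1.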

Compound 4, largest response reached (Emax), in percent of the reference or control that the assay uses: 86.5%
Estimate against measurement, compound 4: 1.5 percentage points below, within the range that was stated.
By their numbers in this assay, from the lowest: compounds 3, 4 and 2 (each within the scatter of the next).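

In this assay, methyl(phenyl)amino in place of morpholin-4-yl on the sulfonyl sulfur gives a number 1.4 percentage points higher from compound 3 to compound 4 (within the scatter). This swap removes the morpholine ring's oxygen and brings in a six-membered aromatic ring of carbon only, yet the maximal response stays within the scatter. Methyl(phenyl)amino in place of (4-cyanophenyl)amino gives a number 4.3 percentage points lower from compound 2 to compound 4 (within the scatter), so compounds 2, 3 and 4 cannot be told apart here, and this position has so far tolerated all three of these groups.

The compounds shown leave open whether a much smaller group such as a plain amine, or one carrying a carboxylic acid, would hold the maximal response at this level. Compound 1 also cannot be placed beside these three, as a single number is lacking for it, given the several entries: the several entries of compound 1 in this assay, 7.85%; 88% (2 entries)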